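A few compounds are considered here, and "the series" means these few. Any claim that something is new, unique, unknown or untested is made for them only; others in the source may bear on it.

Working notes on the vinyl sulfone series. Compound 1 `COc1cccc(S(=O)(=O)/C=C/c2ccccn2)c1` gives 74% in an ADME assay on microsomes from liver (Homo sapiens) for metabolic stability, read by LC-MS, using NADPH, with stated times of 5 min and 30 min, tested at 1 uM; on this read-out lower numbers stand for a less stable compound and higher numbers for a more stable compound. Compound 2 `COc1cccc(S(=O)(=O)/C=C/c2ncccc2F)c1` carries the change fluoro in place of hydrogen on an aromatic carbon on the core of compound 1, and in this assay compound 2 gives 31%; the step is a number 43 percentage points lower from compound 1 to compound 2 (beyond the scatter), a large drop for a single added fluorine.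

Compound 3 `COc1ccc(S(=O)(=O)/C=C/c2cccnc2)cc1` has the same atoms as compound 1 joined differently; the difference between the two cores is not broken down here. In this assay compound 3 gives "not determined" (no result reported), so no number for compound 3 was reported. Compound 4 `COc1ccc(S(=O)(=O)/C=C/c2ccc(F)nc2)cc1` is compound 3 with the change (fluoro in place of hydrogen on an aromatic carbon), the same kind of change as that from compound 1 to compound 2, but the surroundings differ: in compound 2 the fluorine sits ortho to a large group and two atoms from the ring nitrogen, in compound 4 it sits next to the ring nitrogen and para to a large group.

For the measured compounds named here, without a value for compound 3, no step can be computed. For compound 4 the percent remaining is estimated at 50%, between 20% and 85%, a wide band resting only on the range spanned by compound 1 and compound 2.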

Compound 4, percent of the compound remaining: 46%
The estimate for compound 4 lay 4 percentage points above the measured number; measured number inside the range.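

For the compounds shown here, compound 3 carries no number in this assay, so no step from compound 3 to compound 4 can be read. On these data alone, whether fluoro in place of hydrogen next to the ring nitrogen brings a drop like that from compound 1 to compound 2 stays open. No supporting data bear on the result for compound 4.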